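The source may report more compounds than this note shows. Statements on the series, on what has been measured and on what is new or still open speak of the compounds shown alone.

Of the compounds shown here, three built on one shared core have so far been measured in an assay on Sf9 cells for inhibition of protein deacetylase HDAC6 (Homo sapiens), read by fluorescence, with a stated time of 40 min, tested at 100 nM; on this read-out higher numbers stand for more inhibition at the one concentration tested (going by the name of the read-out) and lower numbers for less inhibition. Compound 1 `CCc1ccc(-n2nc(-c3ccccc3)nc2CNc2ccc(C(=O)NO)cc2)cc1` gives 38.3%. Compound 2 `CC(C)c1ccc(-n2nc(-c3ccccc3)nc2CNc2ccc(C(=O)NO)cc2)cc1` gives 52.6%. Compound 3 `O=C(NO)c1ccc(NCc2nc(-c3ccc(F)cc3)nn2-c2ccccc2)cc1` gives 70.9%, the highest of the three numbers, beyond the scatter above compound 2 and still further above compound 1. Going by the values given here, the only step measured between two compounds differing in a single place is a number 14.3 percentage points higher from compound 1 to compound 2 (beyond the scatter). That step concerns a saturated chain carbon, not the aromatic carbon at which the new compound differs, so it offers little guidance for the change considered here.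

Compound 4 `O=C(NO)c1ccc(NCc2nc(-c3cc4ccccc4s3)nn2-c2ccccc2)cc1` has not yet been measured. It differs from compound 3 in one place: 1-benzothiophen-2-yl in place of 4-fluorophenyl on an aromatic carbon. Among the compounds with values here, no measured pair changes this group on its own, so there is no step of the same kind to anchor the expectation, and compounds 1 and 2 differ from compound 3 in more than this one place. The expectation is therefore set close to compound 3, with a wide range. Compound 4 is expected to give about 66%, from 42% to 85%. This estimate means an expected step of a number 4.9 percentage points lower from compound 3 to compound 4 (within the scatter), which is expected to stay within the scatter.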

Compound 4, a percentage reported as inhibition, at one concentration (the size of the read-out at that concentration, not a potency): 65.5%
Estimate against measurement, compound 4: 0.5 percentage points above; the range from low to high includes it.
By their numbers in this assay, from the lowest: compound 1; then compound 2; then compounds 4 and 3 (each within the scatter of the next).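

At the aromatic carbon between two ring nitrogen atoms, putting 1-benzothiophen-2-yl in place of 4-fluorophenyl gives, in this assay, a number 5.4 percentage points lower from compound 3 to compound 4 (within the scatter), so this read-out does not tell the two groups apart at this position. Going by these compounds alone, this is the first measured change at this place, and it shows that a group of 9 heavy atoms, with a five-membered aromatic ring holding sulfur and a six-membered aromatic ring of carbon, can stand where a single six-membered aromatic ring carrying fluorine stood, without a shift beyond the usual scatter. Nothing available explains why these two quite different groups read alike here.

From the compounds shown here alone, both groups tested at this carbon are aromatic, so it remains open whether a saturated ring such as cyclohexyl, a carboxylic acid or an amine would read the same way. Going by these compounds, it is also open whether the two groups would still read alike at other concentrations, since the read-out comes from a single concentration and is not a potency.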